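The compounds below may be only part of what the source reports. "The series", "measured", "known", "first", "only" and "open" are said of these compounds alone.

In a functional assay on GTL 16 cells (Homo sapiens) for cytotoxicity, with a stated time of 72 h (a lower number here means that less compound is needed, a higher number that more compound is needed for the effect), two compounds built on the same core have been measured. Compound 1 `Cc1nc(N)nc2c1C(=O)N[C@@H](c1ccc(F)cc1-c1cccc(O)n1)C2` carries a 6-hydroxypyridin-2-yl group, and its reading of > 10000 nM is a limit of the assay and not a number. Going by the values given here, compound 2 `COc1nc(-c2cc(F)ccc2[C@H]2Cc3nc(N)nc(C)c3C(=O)N2)cnc1N` carries a 5-amino-6-methoxypyrazin-2-yl group at that place and gives 34 nM, the only true number available so far. Among the compounds with values here, the exchange of these two groups produced the one measured step, an at least 290-fold lower number from compound 1 to compound 2 (2.46 log units; beyond the scatter), which is large and beyond the scatter.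

Compound 3 `COc1nc(-c2cc(F)ccc2[C@H]2Cc3nc(N)nc(C)c3C(=O)N2)cs1` changes the same place again, with 2-methoxy-1,3-thiazol-4-yl in place of 5-amino-6-methoxypyrazin-2-yl on an aromatic carbon. Within the data shown here, no measured compound carries a five-membered aromatic ring there. The step shown by compound 2, an at least 290-fold lower number from compound 1 to compound 2 (2.46 log units; beyond the scatter), suggests that the number in this assay can respond strongly to this group. A move towards a higher number is therefore expected, beyond the scatter but well short of that step. This estimate means an expected 5.9-fold higher number from compound 2 to compound 3 (0.77 log units; beyond the scatter). For compound 3 the estimated value is 200 nM, within an expected range of 25 nM to 2500 nM.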

Compound 3, half-maximal effective concentration: 190 nM
Beside the measured number, compound 3's estimate is 1.1-fold (0.02 log units) above it, within the range that was stated.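

In this assay, a five-membered aromatic ring now stands at this place on the aromatic carbon, and the 2-methoxy-1,3-thiazol-4-yl group keeps most of the gain over the 6-hydroxypyridin-2-yl group, with an at least 52-fold lower number from compound 1 to compound 3 (1.72 log units; beyond the scatter). Set against the 5-amino-6-methoxypyrazin-2-yl group, the same ring gives a 5.6-fold higher number from compound 2 to compound 3 (0.75 log units; beyond the scatter), so among the three groups shown, a six-membered aromatic ring is not needed here for a reading far from the limit, although the best number still belongs to compound 2. The reading of compound 1 is a limit and not a number, so the true size of both steps that start from it stays unknown: the limit of > 10000 nM in this assay, at which 1 of the 3 values shown sits.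

The change from compound 2 to compound 3 alters the ring size, the hetero atoms and the hydrogen-bond donor count all at once, and the compounds shown do not separate these changes. From the compounds shown here alone, a 6-methoxypyrazin-2-yl group without the amino group, or a 2-amino-1,3-thiazol-4-yl group, would each change fewer of these features, and how either would read in this assay remains open.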